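The compounds below may be only part of what the source reports. "The series", "measured", "known", "first", "only" and "open" are said of these compounds alone.

Measured so far in a functional assay on HL-60 cells (Homo sapiens) for inhibition, read by CCK-8 assay, with a stated time of 48 h; a lower number here means a stronger inhibitor, a higher number a weaker inhibitor:
- compound 1, `COc1ccc(Oc2ccccc2-c2ccsc2S(=O)(=O)N2CCN(C(=O)Nc3ccc([N+](=O)[O-])cc3)CC2)cc1OC`: > 50000 nM, a limit of the assay
- compound 2, `O=[N+]([O-])c1ccc(NC(=S)NCCNS(=O)(=O)c2ccc(-c3ccccc3O[C@H]3CC[C@@H](O)CC3)s2)cc1`: > 50000 nM, a limit of the assay
- compound 3, `O=S(=O)(NCCNC(=S)Nc1cccc(Cl)c1)c1ccc(-c2ccccc2OCc2ccccc2)s1`: > 50000 nM, a limit of the assay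

Compound 3 stands at the same limit as the other two, so no number places it above or below them; all three sit at the limit of > 50000 nM in this assay, at which 3 of the 3 values shown sit. Compound 4, `O=[N+]([O-])c1cccc(NC(=S)NCCNS(=O)(=O)c2ccc(-c3ccccc3OCc3ccccc3)s2)c1`, is not yet measured. It differs from compound 3 by nitro in place of chloro on an aromatic carbon. For the measured compounds named here, no measured pair in this set shows what such a change does in this assay, and nothing here shows any compound leaving the limit. A step beyond the scatter is not expected in either direction. For compound 4 the expected result is 60000 nM, within 20000 nM to 200000 nM, most likely reported again as a limit; the expected step is a step that the limit leaves unreadable from compound 3 to compound 4.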

Compound 4, half-maximal inhibitory concentration: > 50000 nM
Compound 4 gave a limit, no number; the forecaster's own chance of this, stated with the estimate: 85%; the middle value lies beyond the limit too.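

Compound 3 and compound 4 both stand at a limit in this assay, and no step can be read between them: the limit of > 50000 nM in this assay, at which 4 of the 4 values shown sit. The compounds shown leave open whether any change to the shared core brings a compound off that limit in this assay.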